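This account rests on a few compounds, and the source may have more. Where it says the series, first, only, none or still open, it means among the compounds named here.

Measured so far in an assay on cells for inhibition of sodium/hydrogen exchanger (Oryctolagus cuniculus); on this read-out lower numbers stand for stronger inhibition and higher numbers for weaker inhibition:
- compound 1 `Cc1cc2c(cc1C(=O)N=C(N)N)S(=O)(=O)CCC2C` — 45 nM
- compound 2 `Cc1cc2c(cc1C(=O)N=C(N)N)S(=O)(=O)CC2C(C)C` — 21 nM
- compound 3 `CC(C)=C1CS(=O)(=O)c2cc(C(=O)N=C(N)N)c(C)cc21` — 54 nM

Compound 2 stands lowest of the three numbers in this assay, beyond the scatter to both compound 1 and compound 3. Going by the values given here, none of these pairs differ in one place, so no step is traced between them.

Compound 4 `Cc1cc2c(cc1C(=O)N=C(N)N)S(=O)(=O)CC2` differs from compound 2 by hydrogen in place of isopropyl on a saturated ring carbon. Among the compounds with values here, no measured pair shows this change, so the size of the step is not known from the data. The expectation is a weakening, with the step from compound 2 to compound 4 estimated at a 2.9-fold higher number from compound 2 to compound 4 (0.46 log units; beyond the scatter). Compound 4 is expected to give 60 nM in this assay, within 25 nM to 150 nM.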

Compound 4, half-maximal inhibitory concentration: 60 nM
Compound 4: the middle estimate sits on the measured number at the digits printed, within the range that was stated.
By their numbers in this assay, from the lowest: compound 2; then compounds 1, 3 and 4 (each within the scatter of the next).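

In this assay, going by these compounds alone, hydrogen in place of isopropyl on this saturated ring carbon gives the first step that can be read at one place (a 2.9-fold higher number from compound 2 to compound 4 (0.46 log units; beyond the scatter)), a modest weakening. This position is thus not indifferent to its substituent, and isopropyl gives the stronger inhibition of the two groups compared here. Nothing at hand accounts for the size of this step.
Still open, on these data alone, is how methyl, ethyl or a longer chain on this carbon would compare with isopropyl and hydrogen. An amine or a carboxylic acid at the same place also remains untested within the compounds shown.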